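Triazole series: fluoro for methoxy on the benzylsulfanyl arene

The source may report more compounds than this note shows. Statements on the series, on what has been measured and on what is new or still open speak of the compounds shown alone.

Measured compounds in a functional assay on LNCaP cells (Homo sapiens) for cytotoxicity, read by MTT assay; on this read-out higher numbers stand for weaker inhibition and lower numbers for stronger inhibition:
compound 1 `COc1ccc2cc([C@H](C)c3nnc(SCc4ccc(F)cc4)n3-c3ccc(F)cc3)ccc2c1`, 104000 nM
compound 2 `COc1ccc2cc([C@H](C)c3nnc(SCc4ccc(C)cc4)n3-c3ccc(Cl)cc3)ccc2c1`, 52200 nM
compound 3 `COc1ccc(CSc2nnc([C@@H](C)c3ccc4cc(OC)ccc4c3)n2-c2ccc(Cl)cc2)cc1`, <= 400000 nM

Compound 3 gives only a limit of this assay, <= 400000 nM, so its place among the three is not fixed; the limit of <= 400000 nM in this assay, at which 1 of the 3 values shown sits, marks this. The step that the limit leaves unreadable from compound 2 to compound 3 is therefore unreadable in size.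

Compound 4 `COc1ccc2cc([C@H](C)c3nnc(SCc4ccc(F)cc4)n3-c3ccc(Cl)cc3)ccc2c1` is not yet measured. It differs from compound 3 by fluoro in place of methoxy on an aromatic carbon. Going by the values given here, no measured step covers this exact change, so the expectation rests on the other compounds: compound 2, with a methyl in that place, gives 52200 nM, and compound 1, carrying the same 4-fluorobenzyl group, gives 104000 nM. Compound 4 is therefore expected near those two, at 80000 nM (30000 nM to 250000 nM), which means an expected step that the limit leaves unreadable from compound 3 to compound 4 that cannot be read against the limit of compound 3.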

Compound 4, half-maximal inhibitory concentration: 33900 nM
Estimate against measurement, compound 4: 2.4-fold (0.37 log units) above; measured number inside the range.
By their numbers in this assay, from the lowest: compounds 4, 2 and 1 (each within the scatter of the next, the first and the last beyond it).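

In this assay, fluoro in place of methyl at this position gives a 1.5-fold lower number from compound 2 to compound 4 (0.19 log units; within the scatter), so the compounds shown do not separate these two groups. Chloro in place of fluoro, at a different place in the molecule, gives a 3.1-fold lower number from compound 1 to compound 4 (0.49 log units; beyond the scatter), so the one readable step beyond the scatter lies away from this position. The steps involving compound 3 cannot be read: the limit of <= 400000 nM in this assay, at which 1 of the 4 values shown sits.

Going by these compounds, whether methoxy at this position differs from fluoro or methyl remains open. So does the effect of an amine or a carboxylic acid in place of fluoro.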